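The compounds below may be only part of what the source reports. "The series", "measured", "known", "first", "only" and "open" are said of these compounds alone.

In an in vitro assay on SH-EP1 cells for displacement of a labelled ligand from Neuronal acetylcholine receptor; alpha4/beta2 (Homo sapiens) (on this read-out lower numbers stand for stronger inhibition and higher numbers for weaker inhibition), compound 1 `COc1cncc(C2=CC3CC(C2)CN(C)C3)c1` gives 0.6 nM, compound 2 `COc1cc(C2=CC3CC(C2)CN(C)C3)cnc1Cl` gives 4.4 nM, and compound 3 `COc1cc(C2=CC3CNCC(C2)C3)cnc1Cl` gives 0.4 nM. Compound 2 holds the highest number of the three; the step of a 7.3-fold higher number from compound 1 to compound 2 (0.87 log units; beyond the scatter) and the step of an 11-fold lower number from compound 2 to compound 3 (1.04 log units; beyond the scatter) both lie beyond the scatter. Compound 4 `CN1CC2C=C(c3ccc(Cl)nc3)CC(C2)C1` differs from compound 2 by hydrogen in place of methoxy on an aromatic carbon. Going by the values given here, neither measured step touches the methoxy: one adds a chloro group on an aromatic carbon, the other removes the methyl from the amine nitrogen in the ring, so no measured step bears directly on this change, and the size and direction of the step in this assay this assay remain open. Estimated for compound 4, with a wide range, is 8 nM (2 nM to 40 nM). That estimate amounts to an expected step of a 1.8-fold higher number from compound 2 to compound 4 (0.26 log units; within the scatter).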

Compound 4, inhibition constant: 22 nM
Estimate against measurement, compound 4: 2.8-fold (0.44 log units) below, and the stated range covers the measured number.
By their numbers in this assay, from the lowest: compounds 3 and 1 (each within the scatter of the next); then compound 2; then compound 4.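

In this assay, this aromatic carbon, ortho to a chloro group and two atoms from the ring nitrogen, proves sensitive to the change: hydrogen in place of methoxy gives a 5.0-fold higher number from compound 2 to compound 4 (0.70 log units; beyond the scatter). The result holds for this single pair, which carries the chloro group and the methyl on the amine nitrogen. Nothing shown explains the shift.

As far as these compounds go, whether the step has the same size with hydrogen on the amine nitrogen, as in compound 3, or without the chloro group, as in compound 1, stays open. So does how an ethoxy, hydroxy or fluoro group on this carbon would compare with methoxy and hydrogen.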